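This account rests on a few compounds, and the source may have more. Where it says the series, first, only, none or still open, it means among the compounds named here.

In a functional assay on SW1573 cells (Homo sapiens) for antiproliferative activity, read by sulforhodamine B assay, with a stated time of 48 h (on this read-out lower numbers stand for stronger inhibition of growth and higher numbers for weaker inhibition of growth), compound 3 (`CCCC(C#CC(=O)OC)O/C=C/C(=O)OC`) gives 320 nM and stands lowest of the three measured compounds, against compound 1 (`CCCCCC(C#CC(=O)OC)O/C=C/C(=O)OC`) at 1700 nM and compound 2 (`COC(=O)C#CC(O/C=C/C(=O)OC)C1CCCCC1`) at 2100 nM on the same scale. Compound 4 (`COC(=O)C#CC(O/C=C/C(=O)OC)C(C)(C)C`) has tert-butyl in place of propyl (tert-butyl in place of propyl on a saturated chain carbon bound to an oxygen on an unsaturated carbon and a triple-bonded carbon) on a saturated chain carbon bound to an oxygen on an unsaturated carbon and a triple-bonded carbon. Going by the values given here, two measured steps bear on this change: a 5.3-fold lower number from compound 1 to compound 3 (0.73 log units; beyond the scatter) and a 6.6-fold lower number from compound 2 to compound 3 (0.82 log units; beyond the scatter) are both modest but beyond the scatter. Read in reverse, both show higher numbers for the compounds without propyl. Neither compound carries tert-butyl, so the size of the step remains uncertain. The expected step in this assay is a 2.8-fold higher number from compound 3 to compound 4 (0.45 log units; beyond the scatter) and is somewhat smaller than those two. For compound 4 the estimated value is 900 nM with an expected range from 300 nM to 2500 nM on this scale.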

Compound 4, concentration for 50% growth inhibition: 3000 nM
For compound 4 the middle estimate is 3.3-fold (0.52 log units) below the measured one; measured number above the stated range.
By their numbers in this assay, from the lowest: compound 3; then compounds 1, 2 and 4 (each within the scatter of the next).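

With tert-butyl in place of propyl, a 9.4-fold higher number from compound 3 to compound 4 (0.97 log units; beyond the scatter) in this assay sets propyl apart from a third group at this position. Both a 1.4-fold higher number from compound 2 to compound 4 (0.15 log units; within the scatter) and a 1.8-fold higher number from compound 1 to compound 4 (0.25 log units; within the scatter) lie within the scatter, so tert-butyl, cyclohexyl and pentyl cannot be told apart here, whether the group is branched, a ring or a straight chain. Among these four groups, only propyl stands apart. From the compounds shown here alone, whether a shorter chain such as ethyl or methyl would give a still lower number stays open, as does where butyl would fall. Nothing available here explains why propyl stands apart.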